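The source may report more compounds than this note shows. Statements on the series, on what has been measured and on what is new or still open speak of the compounds shown alone.

Compound 3 `CCCCCCCNc1nccnc1C(=O)NCc1ccccc1` belongs to a set of three close analogues that share one core and differ only in the alkylamino chain. In an ADME assay on HeLa cells (Homo sapiens) for cytotoxicity, read by microscopy, with a stated time of 6 days (a higher number here means that more compound is tolerated, a lower number that less compound is tolerated), compound 3 gives > 100000 nM, which is a limit of the assay. Compound 1 `CCCCNc1nccnc1C(=O)NCc1ccccc1` in this assay likewise gives a limit, > 100000 nM. Compound 2 `CCCCCCNc1nccnc1C(=O)NCc1ccccc1` in this assay also gives a limit, > 100000 nM. The steps among them cannot be sized: a step that the two limits leave unreadable from compound 1 to compound 2, a step that the two limits leave unreadable from compound 1 to compound 3 and a step that the two limits leave unreadable from compound 2 to compound 3, all three values sitting at the limit of > 100000 nM in this assay, at which 3 of the 3 values shown sit.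

Compound 4 `CCCCCNc1nccnc1C(=O)NCc1ccccc1` differs from compound 3 by hydrogen in place of ethyl on a saturated chain carbon, five bonds along the chain from a nitrogen on an aromatic ring. The three steps above bear on this change, and none of them yields a size because the limit of > 100000 nM in this assay, at which 3 of the 3 values shown sit, holds every value shown. Changing the chain on that carbon from hydrogen through methyl, ethyl and propyl has moved none of compounds 1, 2 and 3 off the limit. Compound 4 is therefore expected to stay at that limit, with a number no higher from compound 3 to compound 4 (the limit leaves the size open) as the expected step. The estimate for compound 4 is 100000 nM, ranging from 50000 nM to 200000 nM.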

Compound 4, minimum cytotoxic concentration: > 100000 nM
Compound 4: a limit, no number (the forecaster's own chance of this, stated with the estimate: 90%); the middle value sits exactly at the limit.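

In this assay compound 4 gives > 100000 nM, which is a limit, so no step linking it to compound 1, compound 2 or compound 3 can be read: the limit of > 100000 nM in this assay, at which 4 of the 4 values shown sit.

The compounds shown leave open at what concentration, if any, these four become cytotoxic.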